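Trifluoromethyl in place of hydrogen on compound 2

A few compounds are considered here, and "the series" means these few. Any claim that something is new, unique, unknown or untested is made for them only; others in the source may bear on it.

Compound 2 `O=C1COc2ccc(-c3[nH]c(-c4ccccc4)nc3-c3ccccc3)cc2N1` in a functional assay on MV4-11 cells (Homo sapiens) for cytotoxicity, read by colorimetric assay and MTT assay, with a stated time of 3 days, tested at 20 uM (on this read-out lower numbers stand for a stronger effect and higher numbers for a weaker effect at the one concentration tested), gives 7.6%. Going by the values given here, compound 1 `COc1ccc(-c2nc(-c3ccccc3)c(-c3ccc4c(c3)NC(=O)CO4)[nH]2)cc1` gives 1.2%, and the one step through the pair, a number 6.4 percentage points higher from compound 1 to compound 2 (within the scatter), lies within the scatter, so compound 2 sits together with compound 1 and neither stands apart. Compound 3 `O=C1COc2ccc(-c3[nH]c(-c4ccc(C(F)(F)F)cc4)nc3-c3ccccc3)cc2N1` differs from compound 2 by trifluoromethyl in place of hydrogen on an aromatic carbon. Among the compounds with values here, no measured step touches this ring; the only step recorded concerns another ring and was small. On that basis no move beyond the scatter is expected, and the step from compound 2 to compound 3 is estimated as a number 0.4 percentage points higher from compound 2 to compound 3 (within the scatter). Compound 3 is therefore expected to give about 8%, within 0% to 30%.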

Compound 3, a percentage reported as activity, at one concentration (the size of the read-out at that concentration, not a potency): 0.6%
Beside the measured number, compound 3's estimate is 7.4 percentage points above it, within the range that was stated.
By their numbers in this assay, from the lowest: compounds 3, 1 and 2 (each within the scatter of the next).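

In this assay, this ring now has a measured step: trifluoromethyl, para to a large group, stays within the scatter (a number 7 percentage points lower from compound 2 to compound 3 (within the scatter)). Exchanging methoxy for trifluoromethyl at that place also stays within it (a number 0.6 percentage points lower from compound 1 to compound 3 (within the scatter)), so hydrogen, methoxy and trifluoromethyl are not told apart at this position. Nothing available explains why these groups read alike. Going by these compounds, whether an amine or a carboxylic acid at this place would move the read-out beyond the scatter remains open. On these data alone, whether compound 1, compound 2 and compound 3 would differ in the size of their effect at any other concentration also remains open: the read-out was taken at one concentration only.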